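The source may hold more compounds than are shown below. What is called first, only, known or untested is meant among the compounds shown, and "the series" means these compounds.

Series in a functional assay on K562 cells (Homo sapiens) for inhibition, read by fluorescence, with a stated time of 72 h; a lower number here means a stronger inhibitor of growth, a higher number a weaker inhibitor of growth:
Compound 1 `CC(C)c1nccc2nn(-c3ccccc3)cc12` gives only a limit of the assay, > 100000 nM.
Compound 2 `CCCCc1cc2nn(-c3ccccc3)cc2c(C(C)C)n1` gives 12900 nM.
Compound 3 `CCCCc1cc2nn(-c3ccccc3)cc2cn1` gives 6700 nM.

Compound 2 has the highest of the two numbers; the step of a 1.9-fold lower number from compound 2 to compound 3 (0.28 log units; within the scatter) keeps compound 3 within the scatter of it. Compound 4 `CC(C)c1nc(-c2ccccc2)cc2nn(-c3ccccc3)cc12` differs from compound 2 by phenyl in place of butyl on an aromatic carbon. Going by the values given here, the only step at this carbon is an at least 7.7-fold lower number from compound 1 to compound 2 (0.88 log units; beyond the scatter), where butyl enters in place of hydrogen, and it starts from a compound sitting at the limit of > 100000 nM in this assay, at which 1 of the 3 values shown sits. Among the compounds with values here, no measured step swaps one substituent for another here, so the exchange of butyl for phenyl is uncharted; the expectation is a step of a 1.3-fold lower number from compound 2 to compound 4 (0.11 log units; within the scatter), no larger than the scatter. Compound 4 is therefore estimated at 10000 nM in this assay, within 2500 nM to 40000 nM.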

Compound 4, concentration for 50% growth inhibition: 36800 nM
Estimate against measurement, compound 4: 3.7-fold (0.57 log units) below; the measured number falls inside the stated range.
By their numbers in this assay, from the lowest: compounds 3 and 2 (each within the scatter of the next); then compound 4. At a limit, above all of these: compound 1.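

In this assay, going by these compounds alone, the first direct exchange at the aromatic carbon next to the ring nitrogen gives a 2.9-fold higher number from compound 2 to compound 4 (0.46 log units; beyond the scatter), so this position separates phenyl from butyl. Phenyl in place of hydrogen still gives an at least 2.7-fold lower number from compound 1 to compound 4 (0.43 log units; beyond the scatter), so either group here gives a lower number than hydrogen, butyl the lower of the two. That step is only a bound, since it starts from a limit: the limit of > 100000 nM in this assay, at which 1 of the 4 values shown sits.

Open, from the compounds shown here alone, is where an amine or a longer chain at this carbon would fall, and whether the gap between butyl and phenyl holds with hydrogen in place of isopropyl.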